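The source may hold more compounds than are shown below. What is called first, only, known or untested is meant among the compounds shown, and "the series" means these compounds.

Measured compounds: compound 1 `CNC(=O)c1ccc(NCc2cncn2Cc2ccc(-c3ccccc3)cc2N)cc1-c1ccccc1`, compound 2 `c1ccc(-c2ccc(Cn3cncc3CNc3ccc(-c4nc5ccccc5o4)c(-c4ccccc4)c3)cc2)cc1`, compound 3 `c1ccc(-c2ccc(Cn3cncc3CNc3ccc(-c4cc5ccccc5o4)c(-c4ccccc4)c3)cc2)cc1`.

In a toxicity assay on NIH3T3 cells (Mus musculus) for cytotoxicity, read by resazurin assay (on this read-out lower numbers stand for an effect already at smaller amounts and higher numbers for an effect only at larger amounts of compound), compound 1 gives > 1000 nM, which is a limit of the assay and not a number. In this assay compound 2 gives > 10000 nM, again a limit. In this assay compound 3 gives > 10000 nM, also a limit. Compound 3 therefore stands at the limit of > 10000 nM in this assay, at which 2 of the 3 values shown sit, where two of the three values sit; the third sits at the limit of > 1000 nM in this assay, at which 1 of the 3 values shown sits. Among the measured compounds shown here, the one step between measured compounds, a step that the two limits leave unreadable from compound 2 to compound 3, is left unreadable by the two limits, so no size is known for any change.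

Compound 4 `CNC(=O)c1ccc(NCc2cncn2Cc2ccc(-c3ccccc3)cc2)cc1-c1ccccc1` is not yet measured. It differs from compound 3 by methylcarbamoyl in place of 1-benzofuran-2-yl on an aromatic carbon. For the measured compounds named here, compound 1 also carries a methylcarbamoyl group and shows only a limit, so nothing among the measured compounds points to an effect that appears at smaller amounts. The step from compound 3 to compound 4 is expected to stay unreadable, with a step that the limit leaves unreadable from compound 3 to compound 4 most likely showing no change beyond the scatter. Compound 4 is estimated at 15000 nM in this assay, within 3000 nM to 60000 nM, and it is expected that the assay again reports a limit.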

Compound 4, half-maximal effective concentration: > 1000 nM
Compound 4 was reported as a limit; the forecaster's own chance of this, stated with the estimate: 80%; the middle value does not contradict the limit.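

In this assay compound 4 gives > 1000 nM, which is a limit of the assay and not a number. The steps to compound 4 from compound 1, compound 2 and compound 3 cannot be read, as all four values are limits. The compounds shown leave open at what concentration any of them affects these cells, and whether any of the group exchanges alters that concentration.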